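The source may report more compounds than this note shows. Statements on the series, on what has been measured and on what is new or still open speak of the compounds shown alone.

In a functional assay for inhibition, with Homo sapiens as the target (a higher number here means a weaker inhibitor, a lower number a stronger inhibitor), compound 1 `OCc1cc(-c2ccccc2)c2ccc(OCc3cccc(C4(O)CCOCC4)c3)cc2c1` gives 9 nM and compound 2 `Cn1nnc(-c2cc(-c3ccccc3)c3ccc(OCc4cccc(C5(O)CCOCC5)c4)cc3c2)n1` gives 4 nM as its reading. Compound 3 `OC1(c2cccc(COc3ccc4c(-c5ccoc5)cc(C5=NCCO5)cc4c3)c2)CCOCC1` gives 3 nM as its reading, which lies within the usual scatter of compound 2 but beyond the scatter from compound 1.

Compound 4 `OC1(c2cccc(COc3ccc4c(-c5ccoc5)cc(Cc5nccs5)cc4c3)c2)CCOCC1` has not yet been measured and differs from compound 3 in one group: a group of 6 heavy atoms (4 carbon, 1 nitrogen, 1 sulfur; one five-membered aromatic ring with 2 hetero atoms) in place of a group of 5 heavy atoms (3 carbon, 1 nitrogen, 1 oxygen; one five-membered non-aromatic ring with 2 hetero atoms), on an aromatic carbon on an aromatic carbon meta to a furan-3-yl group. Going by the values given here, no measured pair makes this exact swap, so the evidence is indirect. The closest guide is a 2.3-fold lower number from compound 1 to compound 2 (0.35 log units; beyond the scatter) when 2-methyl-2H-tetrazol-5-yl replaces hydroxymethyl on an aromatic carbon. This is a modest step, and that pair carries no furan-3-yl group, so it offers only thin support.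

Only a small step is therefore expected in this assay and perhaps none beyond the scatter. Among the compounds with values here, a slight lean towards a higher number seems reasonable, as compound 3 reads 3 nM and no measured compound lies clearly lower in this set. The expected change is a 1.7-fold higher number from compound 3 to compound 4 (0.22 log units; within the scatter) on this reasoning. The estimated value for compound 4 is 5 nM with a range of 2 nM to 15 nM for the reading once it is known.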

Compound 4, half-maximal inhibitory concentration: 1 nM
Estimate against measurement, compound 4: 5.0-fold (0.70 log units) above, and the stated range ends above it.
By their numbers in this assay, from the lowest: compound 4; then compounds 3 and 2 (each within the scatter of the next); then compound 1.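

In this assay, placing (1,3-thiazol-2-yl)methyl on this aromatic carbon, meta to a furan-3-yl group, instead of the five-membered non-aromatic ring gives a 3.0-fold lower number from compound 3 to compound 4 (0.48 log units; beyond the scatter) and shows that the reading can still shift beyond the scatter when it is already very low. The earlier step at this carbon, a 2.3-fold lower number from compound 1 to compound 2 (0.35 log units; beyond the scatter), came from a pair without a furan-3-yl group, so this position now responds to a change of group both with and without the furan-3-yl group present. No measurement shown here accounts for the step, and its cause remains unknown.

The step changes the ring and adds the methyl link at the same time, so the compounds shown cannot separate the contribution of the thiazole ring from that of the link, and a 1,3-thiazol-2-yl group attached directly to the aromatic carbon would be needed to tell them apart. They also leave open how an amine, a carboxylic acid or a longer chain carrying the thiazole ring at this carbon would read in this assay.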